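The source may report more compounds than this note shows. Statements on the series, on what has been measured and on what is new or still open speak of the compounds shown alone.

Compound 1 `Cc1c2c(n3c1CC(=O)N(CCN(C)C)CC[C@H](C)Nc1cc-3ccc1C(N)=O)CC(C)(C)CC2=O` and compound 2 `Cc1c2c(n3c1CC(=O)N(C)CC[C@H](C)Nc1cc-3ccc1C(N)=O)CC(C)(C)CC2=O` share one core, and both were tested in an in vitro ADME assay on microsomes from liver (Rattus norvegicus) for metabolic stability; on this read-out lower numbers stand for a shorter-lived compound and higher numbers for a longer-lived compound. In this assay compound 1 gives > 0.5 h, which is a limit of the assay and not a number. In this assay compound 2 gives > 0.5 h, which is also a limit and not a number. Compound 2 therefore has no exact position and stands at the limit of > 0.5 h in this assay, at which 2 of the 2 values shown sit.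

Compound 3 `CC(=O)NCCN1CC[C@H](C)Nc2cc(ccc2C(N)=O)-n2c(c(C)c3c2CC(C)(C)CC3=O)CC1=O` differs from compound 2 by acetamidomethyl in place of hydrogen on a saturated chain carbon bound to an amide-type nitrogen in a ring, with acetamidomethyl in place of hydrogen on a saturated chain carbon bound to an amide-type nitrogen in a ring. For the measured compounds named here, the only measured step at this place is a step that the two limits leave unreadable from compound 1 to compound 2, so it offers no size to carry over. With no readable step to build on, no shift beyond the scatter is expected in this assay, in either direction. The expected step, a step that the limit leaves unreadable from compound 2 to compound 3, is a cautious estimate of no clear direction. For compound 3 the estimated half-life is 0.7 h, with an expected range from 0.35 h to 1.5 h.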

Compound 3, half-life in the Rattus norvegicus assay: > 0.5 h
Compound 3 gave a limit, no number (the forecaster's own chance of this, stated with the estimate: 65%); the middle value lies beyond the limit too.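

No new step can be read among compound 1, compound 2 and compound 3, since in the Rattus norvegicus assay every value is a limit and not a number: the limit of > 0.5 h in the Rattus norvegicus assay, at which 3 of the 3 values shown sit. In a physicochemical assay for solubility (a higher number here means a more soluble compound, a lower number a less soluble compound), compound 2 gives > 100 ug/mL, which is a limit and not a number. In the physicochemical assay compound 3 gives > 100 ug/mL, which is also a limit and not a number. In the physicochemical assay compound 2 and compound 3 therefore give only limits: the limit of > 100 ug/mL in the physicochemical assay, at which 2 of the 2 values shown sit. The compounds shown leave open how far the true half-life and solubility lie beyond these limits, and whether acetamidomethyl in place of hydrogen shifts either.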